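The compounds below may be only part of what the source reports. "The series", "measured", "known", "first", "only" and "open" are said of these compounds alone.

Compound 3 `COc1cccc(CNCCCNc2ccnc3cc(Cc4cc(C)cc(C)c4)ccc23)c1O` gives 23 10^-6 cm/s in an ADME assay for permeability, using PAMPA, with a stated time of 30 min, at pH 7.4 (a lower number here means that the compound crosses the layer more slowly, a higher number that the compound crosses the layer faster), level with compound 2 `Cc1cc(C)cc(Cc2ccc3c(NCCCNCc4ccco4)ccnc3c2)c1`, which gives 23 10^-6 cm/s; both stand far below compound 1 `FC(F)(F)c1ccc(-c2ccc3c(NCCCNCc4ccco4)ccnc3c2)cc1`, which gives 237 10^-6 cm/s. Compound 4 `COc1cccc(CNCCCNc2ccnc3cc(Oc4cccc(N(C)C)c4)ccc23)c1O` differs from compound 3 by 3-(dimethylamino)phenoxy in place of 3,5-dimethylbenzyl on an aromatic carbon. For the measured compounds named here, the one earlier step that exchanged the group at that aromatic carbon, a 10-fold lower number from compound 1 to compound 2 (1.01 log units; beyond the scatter), was large, while no change at the digits printed from compound 2 to compound 3 (within the scatter) at the other end of the chain left the number unchanged. A shift is therefore expected from the present exchange at the same aromatic carbon, a 1.3-fold lower number from compound 3 to compound 4 (0.11 log units; within the scatter), though its direction is uncertain. Compound 4 is thus estimated at 18 10^-6 cm/s, with a range from 6 10^-6 cm/s to 55 10^-6 cm/s.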

Compound 4, apparent permeability: 317 10^-6 cm/s
Beside the measured number, compound 4's estimate is 18-fold (1.25 log units) below it; the whole stated range lies below it.
By their numbers in this assay, from the lowest: compounds 2 and 3 (each within the scatter of the next); then compounds 1 and 4 (each within the scatter of the next).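

In this assay, for the compounds shown here, the exchange gives a 14-fold higher number from compound 3 to compound 4 (1.14 log units; beyond the scatter), so this aromatic carbon can move the number up as well as down; the only earlier exchange here lowered it. The rise occurs with the 2-hydroxy-3-methoxyphenyl group at the far end of the chain. The entering group brings a nitrogen, an oxygen and hydrogen-bond acceptors that the leaving group lacks, but no measurement here gives a reason for the rise.

Two features change together: the oxygen link and the dimethylamino group. A 3-(dimethylamino)benzyl or 3,5-dimethylphenoxy group at this carbon would help to separate them.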